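ATM inhibition: from a benzyloxy to a carbamate-bearing ether

The source may hold more compounds than are shown below. What is called first, only, known or untested is meant among the compounds shown, and "the series" means these compounds.

This account concerns two quinazoline-type compounds measured in an assay on MCF7 cells for inhibition of Serine-protein kinase ATM (Homo sapiens), read by immunofluorescence, with a stated time of 1 h (on this read-out higher numbers stand for weaker inhibition and lower numbers for stronger inhibition), and one still to be measured. Compound 1 `COc1cc2nc(N)nc(-n3nc(-c4ccccn4)nc3N)c2cc1OC` gives 2100 nM in this assay. Within the data shown here, compound 2 `COc1cc2ncnc(-n3nc(-c4ccccn4)nc3N)c2cc1OCc1ccccc1` gives 8600 nM and stands at the highest of the two numbers, the weaker of the two, with compound 1 its only neighbour at a lower number beyond the scatter. Compounds 1 and 2 differ in more than one place, so no single step between them is defined; only their two values are shown.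

Compound 3 `COc1cc2ncnc(-n3nc(-c4ccccn4)nc3N)c2cc1OCCNC(=O)OC(C)(C)C` is the step onward from compound 2. The change is ((tert-butoxycarbonyl)amino)methyl in place of phenyl on a saturated chain carbon bound to an oxygen on an aromatic ring. Nothing measured here bears on such a group in that place, so the direction of any step is open. The step from compound 2 to compound 3 is expected to be small, within the scatter, with an expected change of a 1.2-fold lower number from compound 2 to compound 3 (0.09 log units; within the scatter). Compound 3 is therefore estimated at 7000 nM in this assay, within a range of 2000 nM to 25000 nM.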

Compound 3, half-maximal inhibitory concentration: 800 nM
Beside the measured number, compound 3's estimate is 8.8-fold (0.94 log units) above it; measured number below the stated range.
By their numbers in this assay, from the lowest: compound 3; then compound 1; then compound 2.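

In this assay, this position on the shared core is shown not to be indifferent to what it carries: benzyloxy to 2-((tert-butoxycarbonyl)amino)ethoxy gives an 11-fold lower number from compound 2 to compound 3 (1.03 log units; beyond the scatter), a large step and the only one here between compounds that differ in one place. The phenyl ring is therefore not required at this position for the lower number, since the entering ((tert-butoxycarbonyl)amino)methyl has no ring, though it does bring a nitrogen, two oxygens, a double bond outside aromatic rings and a hydrogen-bond donor that phenyl lacks. Nothing available connects the step to any one of these differences or explains it.

The compounds shown leave open whether the step belongs to the carbamate or to the two-carbon chain alone, a question that the free primary amine, an acetamide or a simple methoxyethyl ether at the same oxygen would address. They also leave open how far the chain can be taken, as a longer chain or a carboxylic acid at its end would show, and whether an amino group added to the core of compound 3 would change its number.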